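The compounds below may be only part of what the source reports. "The series", "measured", "known", "first", "only" and "open" are said of these compounds alone.

Compound 1 `CC(C)=CCOc1cc(=O)n(CCCO)c2c1CC(CC=C(C)C)C(C)(C)C2` carries a 2-methylprop-1-en-1-yl group on a saturated chain carbon bound to an oxygen on an aromatic ring. In a functional assay on PANC-1 cells (Homo sapiens) for inhibition, read by MTT assay, with a stated time of 24 h, tested at 10 uM (on this read-out lower numbers stand for less inhibition and higher numbers for more inhibition at the one concentration tested (going by the name of the read-out)), compound 1 gives 7.5%, the highest of the three numbers in hand, though its separation from the other two lies within the scatter. Compound 3 `CC(C)=CCC1Cc2c(OCCCNC(=O)c3ccco3)cc(=O)n(CCCO)c2CC1(C)C` gives 4.3% in this assay, and the step of a number 3.2 percentage points lower from compound 1 to compound 3 (within the scatter) replaces the same 2-methylprop-1-en-1-yl group with a longer chain ending in an amide. Compound 2 `CC(C)=CCC1Cc2c(OCCCNS(=O)(=O)c3ccc(Br)cc3)cc(=O)n(CCCO)c2CC1(C)C` gives 3.7% in this assay; the step of a number 0.6 percentage points higher from compound 2 to compound 3 (within the scatter) swaps a sulfonyl group for a carbonyl group on the amine nitrogen. All three numbers sit low and close together.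

Compound 4 `COc1ccc(OCCCOc2cc(=O)n(CCCO)c3c2CC(CC=C(C)C)C(C)(C)C3)cc1` differs from compound 1 by 2-(4-methoxyphenoxy)ethyl in place of 2-methylprop-1-en-1-yl on a saturated chain carbon bound to an oxygen on an aromatic ring. The step that bears most directly on it is a number 3.2 percentage points lower from compound 1 to compound 3 (within the scatter), which acts at the same place and stays within the scatter; the step of a number 0.6 percentage points higher from compound 2 to compound 3 (within the scatter) likewise shows no movement. No change of the chain on this oxygen has so far moved the read-out beyond the scatter, so no step beyond the scatter is expected here either, in either direction. Compound 4 is therefore estimated at 6% in this assay, within 0% to 15%, which means an expected step of a number 1.5 percentage points lower from compound 1 to compound 4 (within the scatter).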

Compound 4, a percentage reported as inhibition, at one concentration (the size of the read-out at that concentration, not a potency): 4.1%
Estimate against measurement, compound 4: 1.9 percentage points above; low and high end bracket the measured number.
By their numbers in this assay, from the lowest: compounds 2, 4, 3 and 1 (each within the scatter of the next).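

Working notes on the chain on the oxygen: in this assay, the step of a number 3.4 percentage points lower from compound 1 to compound 4 (within the scatter) extends the test to a much larger group, 2-(4-methoxyphenoxy)ethyl, with 11 heavy atoms and one six-membered aromatic ring of carbon only, and the read-out still stays within the scatter. The chain end can now be compared directly: a number 0.2 percentage points lower from compound 3 to compound 4 (within the scatter) and a number 0.4 percentage points higher from compound 2 to compound 4 (within the scatter) both stay within the scatter, so among these compounds a 4-methoxyphenoxy end reads the same in this assay as the amide and sulfonamide ends, and an amine nitrogen in the chain is not needed to give these low numbers. No supporting data bear on why this position shows so little response.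

Still open, going by these compounds, is whether any group on this oxygen can lift the number beyond the scatter, for example a chain ending in a tertiary amine or a carboxylic acid, or a longer chain. The compounds shown also share the rest of the core, so a change elsewhere, such as replacing the 3-hydroxypropyl group with a carboxylic acid chain, remains untested in this series.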